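This account rests on a few compounds, and the source may have more. Where it says the series, first, only, none or still open, it means among the compounds named here.

Values in a toxicity assay on CCRF-CEM cells (Homo sapiens) for cytotoxicity (on this read-out lower numbers stand for higher toxicity in this test and higher numbers for lower toxicity in this test), for the measured compounds:

Compound 1 `CCc1cccc2c1nc(-c1c(F)cccc1F)n2Cc1c(F)cccc1F`: 26.1 uM
Compound 2 `Fc1cccc(F)c1Cn1c(-c2c(F)cccc2F)nc2c(Br)cccc21`: 24.5 uM
Compound 3 `CC(=O)N(C)c1cccc2c1nc(-c1c(F)cccc1F)n2Cc1c(F)cccc1F`: > 100 uM (a limit, not a number)

Compound 3 stands only at a limit (the limit of > 100 uM in this assay, at which 1 of the 3 values shown sits), so no exact number is known for it. The step in question puts carbamoyl in place of acetyl(methyl)amino on the same aromatic carbon, which leads to compound 4 `NC(=O)c1cccc2c1nc(-c1c(F)cccc1F)n2Cc1c(F)cccc1F` with the difference carbamoyl in place of acetyl(methyl)amino on an aromatic carbon counted in full. Within the data shown here, two measured steps bear on this place, an at least 3.8-fold higher number from compound 1 to compound 3 (0.58 log units; beyond the scatter) and an at least 4.0-fold higher number from compound 2 to compound 3 (0.61 log units; beyond the scatter) and both are at least modest, while a 1.1-fold lower number from compound 1 to compound 2 (0.03 log units; within the scatter) does not separate ethyl from bromo. Among the measured compounds shown here, no measured step tests carbamoyl itself. Compound 4 keeps a carbonyl on that carbon, as compound 3 does, so it is expected to retain part of the shift seen in an at least 4.0-fold higher number from compound 2 to compound 3 (0.61 log units; beyond the scatter) without necessarily reaching the limit. In this assay the expected move is small and towards a lower number, estimated as an at least 1.4-fold lower number from compound 3 to compound 4 (0.15 log units; that floor lies within the scatter) overall. The estimate for compound 4 is 70 uM (expected range 25 uM to 150 uM).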

Compound 4, half-maximal toxic concentration: > 100 uM
Compound 4: no number, only a limit (the forecaster's own chance of this, stated with the estimate: 40%); middle value at least 1.4-fold (0.15 log units) from the limit.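

In this assay compound 4 gives > 100 uM, which is a limit of the assay and not a number. Acetyl(methyl)amino is therefore not the only group on this aromatic carbon that separates from ethyl and bromo, as carbamoyl, with fewer heavy atoms and a hydrogen-bond donor that acetyl(methyl)amino lacks, does so too: an at least 3.8-fold higher number from compound 1 to compound 4 (0.58 log units; beyond the scatter) and an at least 4.0-fold higher number from compound 2 to compound 4 (0.61 log units; beyond the scatter). The step between the two amide-bearing compound 3 and compound 4 cannot be read: the limit of > 100 uM in this assay, at which 2 of the 4 values shown sit.

Going by these compounds, how far compound 3 and compound 4 truly lie past that limit, and whether they differ at all, stays open. So does whether an amine or a carboxylic acid on this aromatic carbon would also separate from ethyl and bromo.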